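This account rests on a few compounds, and the source may have more. Where it says the series, first, only, none or still open, it means among the compounds named here.

Among the measured compounds shown here, compound 2 `O=C(O)c1csc(-n2nc(C3=CCCCC3)c3ccccc32)n1` stands at the lower of the two numbers measured so far: in an assay on isolated protein for antagonist activity at prostaglandin E2 receptor EP1 subtype (Homo sapiens), read by reporter gene assay (a higher number here means a weaker inhibitor, a lower number a stronger inhibitor), compound 2 gives 4 nM, and compound 1 `O=C(O)c1csc(-n2nc(-c3ccc(Cl)cc3)c3ccccc32)n1` gives 12 nM. For the measured compounds named here, the one measured step at this position, a 3.0-fold lower number from compound 1 to compound 2 (0.48 log units; beyond the scatter), is the only comparison that bears on the next change. Compound 3 `O=C(O)c1csc(-n2nc(-c3cncnc3)c3ccccc32)n1` differs from compound 2 by pyrimidin-5-yl in place of cyclohex-1-en-1-yl on an aromatic carbon. That step from compound 1 to compound 2 went toward a lower number when an aromatic six-membered ring gave way to the non-aromatic cyclohex-1-en-1-yl; the present change puts an aromatic six-membered ring back in the same place, now with two nitrogen atoms in it. A modest move toward a higher number is therefore expected in this assay, about a 3.8-fold higher number from compound 2 to compound 3 (0.57 log units; beyond the scatter). Compound 3 is accordingly estimated to give 15 nM, with a range from 4 nM to 60 nM.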

Compound 3, half-maximal inhibitory concentration: > 100 nM
Compound 3: no number, only a limit; the forecaster's own chance of this, stated with the estimate: 5%; at least 6.6-fold (0.82 log units) between middle value and limit.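

In this assay compound 3 carries a limit of the assay and not a number: the limit of > 100 nM in this assay, at which 1 of the 3 values shown sits. Among the compounds shown here, this position on the aromatic carbon had so far held both 4-chlorophenyl and cyclohex-1-en-1-yl at low numbers, but pyrimidin-5-yl gives an at least 25-fold higher number from compound 2 to compound 3 (1.39 log units; beyond the scatter) and an at least 8.3-fold higher number from compound 1 to compound 3 (0.92 log units; beyond the scatter). An aromatic six-membered ring as such therefore does not set the higher number, since compound 1 also carries one; what sets compound 3 apart from compound 1 here is the ring with two nitrogen atoms and no chlorine.

From the compounds shown here alone, how far compound 3 lies past the limit stays open. Also open, going by these compounds, is how a plain phenyl or a pyridin-3-yl ring would read here, and so whether a single ring nitrogen would already give a higher number.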